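Ethyl-to-hydrogen truncation on two cores, growth inhibition

The source may hold more compounds than are shown below. What is called first, only, known or untested is meant among the compounds shown, and "the series" means these compounds.

Measured compounds:
compound 1 `COc1ccc(Nc2nccc(-c3cn(C)c4ccccc34)n2)c(OC)c1` gives 3410 nM
compound 2 `CCCn1cc(-c2ccnc(Nc3ccc(OC)cc3OC)n2)c2ccccc21` gives 3620 nM
compound 3 `CCCCOc1nc(C)c(-c2ccnc(Nc3ccc(OC)cc3OC)n2)s1` gives 7860 nM

All three were tested in a functional assay on MV4-11 cells (Homo sapiens) for inhibition, read by resazurin assay, with a stated time of 72 h; a lower number here means a stronger inhibitor of growth, a higher number a weaker inhibitor of growth. Compounds 1 and 2 share one core, compound 3 carries another; the difference between the two cores is not broken down here. Compound 3 stands highest of the three, and its gap to each of the other two is beyond the scatter.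

Within the first core, the change hydrogen in place of ethyl on a saturated chain carbon bound to an aromatic nitrogen gave a 1.1-fold lower number from compound 2 to compound 1 (0.03 log units; within the scatter), a step that counts for nothing.

Compound 4 `CCOc1nc(C)c(-c2ccnc(Nc3ccc(OC)cc3OC)n2)s1` is not yet measured. It differs from compound 3 by hydrogen in place of ethyl on a saturated chain carbon, two bonds along the chain from an oxygen on an aromatic ring. Within the data shown here, this is the same kind of change as the one from compound 2 to compound 1, but not the same: there the place was on a saturated chain carbon bound to an aromatic nitrogen, here it is two bonds along the chain from an oxygen on an aromatic ring, and the core is different. Among the measured compounds shown here, with only that one precedent, a flat step is expected for compound 4, a 1.0-fold lower number from compound 3 to compound 4 (0.02 log units; within the scatter), resting on compound 2 to compound 1 having given a 1.1-fold lower number from compound 2 to compound 1 (0.03 log units; within the scatter). Compound 4 is therefore estimated at 7500 nM, in a range of 3000 nM to 19000 nM.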

Compound 4, concentration for 50% growth inhibition: 3890 nM
Compound 4: the middle estimate sits 1.9-fold (0.29 log units) above what was measured, and the stated range covers the measured number.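

In this assay, shortening butoxy to ethoxy gave a 2.0-fold lower number from compound 3 to compound 4 (0.31 log units; beyond the scatter), a modest step on the core of compound 3. Set beside the same kind of change on the core of compound 1, the two steps cannot be told apart: the same change on two cores in this assay, a 1.1-fold lower number (0.03 log units; within the scatter) from compound 2 to compound 1 and a 2.0-fold lower number (0.31 log units; beyond the scatter) from compound 3 to compound 4, 1.9-fold (0.28 log units) apart, within the scatter of two such steps. This shows no measurable dependence of the change on the core, but with one pair per core it does not show that the step has the same size on both, and the change also sits at a different place on each core, so nothing follows for a third core.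

The compounds shown leave open whether shortening further to a methoxy group, or lengthening to a chain beyond butoxy, would move the number on the core of compound 3. Also open, going by these compounds, is how a terminal amine or carboxylic acid on that chain would read in this assay.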